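Chain in place of ring on a quinoline-type ester scaffold's amine arm

The source may report more compounds than this note shows. Statements on the series, on what has been measured and on what is new or still open speak of the compounds shown alone.

The account concerns a small set of closely related compounds tested in an ADME assay on COS-7 cells (Chlorocebus aethiops) for cytotoxicity, read by MTT assay, with a stated time of 24 h; on this read-out higher numbers stand for lower toxicity in this test and lower numbers for higher toxicity in this test. Compound 1 `CCOC(=O)c1c(CN2CCCC2)nc2ccc(Cl)cc2c1-c1ccccc1` was measured in this assay and gives 490000 nM. Within the data shown here, compound 2 `O=C(O)c1c(CNCc2ccccc2)nc2ccc(Cl)cc2c1-c1ccccc1` carries a free acid and a benzylamine arm on the shared core; in this assay compound 2 has "not determined" (no result reported), so no single number places it on this scale, and no step from it to any measured compound can be sized.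

Compound 3 `CC(=O)NCCCCCCNCc1nc2ccc(Cl)cc2c(-c2ccccc2)c1C(=O)O` is the next member. It differs from compound 2 as follows: 5-acetamidopentyl in place of phenyl on a saturated chain carbon bound to an amine nitrogen. Among the measured compounds shown here, since compound 2 has no number in this assay, no step from compound 2 to compound 3 can be computed from the data, and its size and direction remain open; the only anchor is compound 1 with 490000 nM, which is a weakly toxic reading.

On that anchor alone, compound 3 is expected to give about 350000 nM in this assay, with a plausible range from 120000 nM to 1000000 nM.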

Compound 3, half-maximal cytotoxic concentration: 771000 nM
Estimate against measurement, compound 3: 2.2-fold (0.34 log units) below; the range from low to high includes it.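

Among these compounds, compound 2 has no number in this assay, so no step from compound 2 to compound 3 can be read from these results. The compounds shown leave open how the change from benzyl to 6-acetamidohexyl alters the reading on this scale. No measured evidence bears on the result of compound 3.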